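A Benzyl Group Enters on the Amino Nitrogen of Compound 3

The source may report more compounds than this note shows. Statements on the series, on what has been measured and on what is new or still open speak of the compounds shown alone.

Compound 1 `CCCSc1nc(N)cc(OCc2ccccc2)n1` gives 54200 nM in a functional assay on LoVo cells (Homo sapiens) for antiproliferative activity, read by MTT assay, with a stated time of 72 h; a lower number here means a stronger inhibitor of growth, a higher number a weaker inhibitor of growth.
Compound 2 `CNc1ccc(-c2cn3c(OC)cc(OC)nc3n2)cc1` gives > 100000 nM, which is a limit of this assay and not a number.
Compound 3 `Cc1ccc2nc(-c3ccc(N)cc3)cn2c1` gives 65200 nM.

Of the two numbers in hand, compound 3 and compound 1 lie within the scatter of each other, so the two cannot be told apart, and for compound 2 only a limit is known (the limit of > 100000 nM in this assay, at which 1 of the 3 values shown sits). For the measured compounds named here, no step between measured compounds that differ in one place is available, so the effect of any single change on this assay remains untested.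

Compound 4 `Cc1ccc2nc(-c3ccc(NCc4ccccc4)cc3)cn2c1` differs from compound 3 in one place: benzyl in place of hydrogen on a nitrogen on an aromatic ring, turning amino into benzylamino. Compound 1 also carries a benzyl group, there on an oxygen, and gives a value close to that of compound 3, but nothing connects the two changes directly.

Going by the values given here, with no measured step to lean on, a step from compound 3 to compound 4 of a 1.4-fold lower number from compound 3 to compound 4 (0.16 log units; within the scatter) is expected, which stays within the scatter. Compound 4 is therefore estimated at 45000 nM, with a range from 15000 nM to 100000 nM.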

Compound 4, concentration for 50% growth inhibition: 42600 nM
The estimate for compound 4 lay 1.1-fold (0.02 log units) above the measured number, and the stated range covers the measured number.
By their numbers in this assay, from the lowest: compounds 4, 1 and 3 (each within the scatter of the next). At a limit, above all of these: compound 2.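

For the compounds shown here, this is the first step that can be read between two measured compounds. In this assay, benzyl in place of hydrogen on a nitrogen on an aromatic ring, turning amino into benzylamino, gives a difference that stays within the scatter (a 1.5-fold lower number from compound 3 to compound 4 (0.18 log units; within the scatter)), so compound 3 and compound 4 cannot be told apart, and this nitrogen can carry a benzyl group with no change that this assay can resolve. Nothing in the evidence at hand bears on this result, which therefore stands as an observation without an explanation.

Going by these compounds alone, the single step leaves open whether this nitrogen would stay as insensitive with a different group, such as acetyl, a longer phenylpropyl chain, or a benzyl ring carrying a carboxylic acid, since a benzyl group alone cannot show how far this tolerance reaches. It also leaves open what the methyl group on the core shared by compound 3 and compound 4 contributes, and whether replacing it with a chlorine or an amine would shift the numbers beyond the scatter.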